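Glucagon receptor antagonists: phenyl exchange from compound 2 to compound 4

The source may hold more compounds than are shown below. What is called first, only, known or untested is meant among the compounds shown, and "the series" means these compounds.

Three compounds of the series have numbers in a functional assay on CHO cells for antagonist activity at Glucagon receptor (Homo sapiens), read by cAMP accumulation, with stated times of 30 min and 45 min; a higher number here means a weaker inhibitor, a lower number a stronger inhibitor. Compound 1 `CC(C)(C)CC[C@H](c1ccc(C(=O)NCc2nn[nH]n2)cc1)N1C(=O)C(c2cncc(Cl)c2)=N[C@]12CC[C@@H](C(C)(C)C)CC2` gives 480 nM. Compound 2 `C[C@H](c1ccc(C(=O)NCCC(=O)O)cc1)N1C(=O)C(c2cccc(OC(F)(F)F)c2)=N[C@]12CC[C@@H](C(C)(C)C)CC2` gives 840 nM. Compound 3 `CC1(CC[C@H](c2ccc(C(=O)NCc3nn[nH]n3)cc2)N2C(=O)C(c3cc(Cl)cc(Cl)c3)=N[C@]23CC[C@@H](C(C)(C)C)CC3)CC1` gives 100 nM. Among these three, compound 2 has the highest number. Compound 1 sits closest to compound 2, and the gap between the two lies within the usual scatter of repeated measurements, so no order between them is claimed. Compound 3 lies furthest from compound 2, with a lower number in this assay that is beyond the scatter.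

Compound 4 `C[C@H](c1ccc(C(=O)NCCC(=O)O)cc1)N1C(=O)C(c2ccccc2F)=N[C@]12CC[C@@H](C(C)(C)C)CC2` has not yet been measured. It differs from compound 2 in one place: 2-fluorophenyl in place of 3-(trifluoromethoxy)phenyl on a carbon with a double bond to nitrogen. Within the data shown here, no step between measured compounds involves this change, so nothing measured tells its size or direction. The expectation is a small step from compound 2 to compound 4 toward a higher number in this assay, of the order of a 1.4-fold higher number from compound 2 to compound 4 (0.15 log units; within the scatter), not clearly beyond the scatter. For compound 4 the estimated number in this assay is 1200 nM, with a range from 400 nM to 3500 nM.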

Compound 4, half-maximal inhibitory concentration: 350 nM
Compound 4: the middle estimate sits 3.4-fold (0.54 log units) above what was measured; the whole stated range lies above it.
By their numbers in this assay, from the lowest: compound 3; then compounds 4, 1 and 2 (each within the scatter of the next, the first and the last beyond it).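

In this assay, among these compounds, the exchange on the carbon with a double bond to nitrogen gives a 2.4-fold lower number from compound 2 to compound 4 (0.38 log units; beyond the scatter) and is the first step read at this position, which shows that the number responds to the aryl group carried there. The 2-fluorophenyl, with fewer heavy atoms than 3-(trifluoromethoxy)phenyl and without the hydrogen-bond acceptor counted in the group that leaves, is accepted at this position, so within this pair the larger group is not needed for the stronger inhibition. Nothing on hand bears on what lies behind this step, which stands as an observation on one pair of compounds.

The step changes the substituent and its place on the phenyl ring together, so the compounds shown do not separate the part played by the fluorine from that played by the loss of the trifluoromethoxy group. As far as these compounds go, an unsubstituted phenyl, a 3-fluorophenyl or a 2-(trifluoromethoxy)phenyl on the same carbon would address this, and whether the step holds with a tetrazole in place of the carboxylic acid also remains open.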